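A few compounds are considered here, and "the series" means these few. Any claim that something is new, unique, unknown or untested is made for them only; others in the source may bear on it.

Measured compounds:
- compound 1, `COc1ccc(-c2ccc(OCc3cc(C(=O)O)oc3C)cc2)cc1OC`: 2800 nM
- compound 2, `CC(=O)c1ccc(-c2ccc(OCc3cc(C(=O)O)oc3C)cc2)cc1`: 150 nM
- compound 3, `COc1ccc(-c2ccc(OCc3cc(C(=O)NS(=O)(=O)c4ccc(CN)cc4)oc3C)cc2)cc1`: 100 nM

In an assay on cells for displacement of a labelled ligand from prostaglandin E2 receptor EP4 subtype (Homo sapiens), read by scintillation counting (a higher number here means a weaker inhibitor, a lower number a stronger inhibitor), compound 3 gives the lowest of the three numbers. Its value and that of compound 2 lie within the scatter of each other, so the two cannot be ranked; compound 1, by contrast, sits well beyond the scatter, and compound 3 is clearly the stronger of that pair. Since no two of the three compounds differ in a single place, none of these gaps can be pinned to one structural feature.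

Going by the values given here, compound 4, `COc1ccc(-c2ccc(OCc3cc(C(=O)NS(=O)(=O)c4ccc(C)cn4)oc3C)cc2)cc1`, is the first compound here to alter the group on the sulfonyl sulfur: 5-methylpyridin-2-yl in place of 4-(aminomethyl)phenyl on a sulfonyl sulfur. Among the compounds with values here, no measured pair isolates this kind of change, so the step from compound 3 carries no direct precedent. The shared core and the acyl sulfonamide linkage are untouched, and on that basis the step is expected to be small, with no clear direction beyond the scatter. Compound 4 is therefore estimated at 120 nM in this assay, within a range from 35 nM to 450 nM, which corresponds to an expected step of a 1.2-fold higher number from compound 3 to compound 4 (0.08 log units; within the scatter).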

Compound 4, inhibition constant: 15 nM
Compound 4: middle estimate off by 8.0-fold (0.90 log units), on the high side; measured number outside the range, below it.
By their numbers in this assay, from the lowest: compound 4; then compounds 3 and 2 (each within the scatter of the next); then compound 1.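

In this assay, the group on the sulfonyl sulfur turns out to matter: 5-methylpyridin-2-yl in place of 4-(aminomethyl)phenyl gives a 6.7-fold lower number from compound 3 to compound 4 (0.82 log units; beyond the scatter) with the rest of the molecule unchanged. This is the first gap among the compounds shown that can be pinned to one place, and it lies beyond the scatter. Nothing available here explains the size of this step.

On these data alone, the change alters the ring and its substituent together, so it remains open whether the ring nitrogen or the loss of the aminomethyl group carries the step; a phenyl ring bearing a methyl, or a pyridine ring bearing an aminomethyl, would separate the two. As far as these compounds go, how far the position tolerates other groups on the sulfonyl sulfur, such as a simple alkyl chain, also stays open.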